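From Hydroxy to Acetoxy on a Shared Core

The source may report more compounds than this note shows. Statements on the series, on what has been measured and on what is new or still open speak of the compounds shown alone.

In an ADME assay on L6 cells (Rattus norvegicus) for cytotoxicity, read by resazurin assay, with a stated time of 70 h (a higher number here means a weaker inhibitor, a lower number a stronger inhibitor), compound 1 (`COc1cc(CN2c3ccc(O)cc3C(C)=CC2(C)C)cc(OC)c1`) gives a value of 11000 nM in this series. Compound 2 (`CC1=CC(C)(C)N(Cc2ccc(C)cc2)c2ccc(O)cc21`) gives 8100 nM in the same test. Among the measured compounds shown here, these two numbers lie within the scatter of each other, so compound 1 stands level with the only other compound measured so far.

Compound 3 (`COc1cc(CN2c3ccc(OC(C)=O)cc3C(C)=CC2(C)C)cc(OC)c1`) keeps the core of compound 1 and differs from it in one place. The change is acetyl in place of hydrogen on an oxygen on an aromatic ring, which reads as hydroxy to acetoxy.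

For the measured compounds named here, no measured pair shows this change, so the data give no direct guide to its size or direction. The expectation therefore rests on compound 1 at 11000 nM in this assay and on the level of compound 2 at 8100 nM in that test. The expected 1.1-fold lower number from compound 1 to compound 3 (0.04 log units; within the scatter) stays within the scatter, with no direction favoured. In this assay the estimated value for compound 3 is 10000 nM (expected range 4000 nM to 28000 nM).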

Compound 3, half-maximal inhibitory concentration: 25000 nM
Compound 3: middle estimate off by 2.5-fold (0.40 log units), on the low side; low and high end bracket the measured number.
By their numbers in this assay, from the lowest: compounds 2 and 1 (each within the scatter of the next); then compound 3.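

In this assay, acetyl in place of hydrogen on the oxygen on the aromatic ring gives a 2.3-fold higher number from compound 1 to compound 3 (0.36 log units; beyond the scatter), a modest step toward a weaker inhibitor. Among the compounds shown here, this is the first measured step, and it shows that this position responds to change, which compounds 1 and 2 could not show, since both carry the hydroxy group and differ elsewhere. Nothing at hand accounts for the size or direction of this step.

The compounds shown leave open whether the step is particular to acetoxy or would also follow from another group on the same oxygen, such as a methyl ether, a longer acyl chain or a carbamate. They also leave open whether hydroxy to acetoxy would give a step of similar size and the same direction when made on compound 2, so this single pair cannot yet be read as a pattern across the series.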